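From aminocarbamoyl to carboxy on the shared core

A few compounds are considered here, and "the series" means these few. Any claim that something is new, unique, unknown or untested is made for them only; others in the source may bear on it.

Measured in a functional assay on HepG2 cells (Homo sapiens) for cytotoxicity, read by MTT assay, with a stated time of 48 h; a lower number here means a stronger inhibitor, a higher number a weaker inhibitor:
- compound 1 `Cc1n[nH]c2c1C(c1ccc(N(C)C)cc1)C(C(=O)NN)=C(N)N2`: 66400 nM
- compound 2 `Cc1n[nH]c2c1C(c1ccc(N(C)C)cc1)C=C(N)N2`: 20600 nM

Compound 1 holds the higher number of the two. Compound 3 `Cc1n[nH]c2c1C(c1ccc(N(C)C)cc1)C(C(=O)O)=C(N)N2` carries hydroxy in place of aminoamino on a carbonyl carbon, which also reads as aminocarbamoyl to carboxy. Within the data shown here, the one measured step is a 3.2-fold lower number from compound 1 to compound 2 (0.51 log units; beyond the scatter), with hydrogen in place of aminocarbamoyl on a double-bonded ring carbon. It bears only loosely: there the whole group goes, whereas compound 3 keeps the carbonyl. In this assay, no shift beyond the scatter is therefore expected. The expected step is a 1.3-fold lower number from compound 1 to compound 3 (0.12 log units; within the scatter). Compound 3 is estimated at 50000 nM, with an expected range of 16000 nM to 150000 nM.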

Compound 3, half-maximal inhibitory concentration: 39700 nM
For compound 3 the middle estimate is 1.3-fold (0.10 log units) above the measured one; the range from low to high includes it.
By their numbers in this assay, from the lowest: compounds 2, 3 and 1 (each within the scatter of the next, the first and the last beyond it).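

In this assay, hydroxy in place of aminoamino on the carbonyl carbon gives a 1.7-fold lower number from compound 1 to compound 3 (0.22 log units; within the scatter), while carboxy in place of hydrogen on the double-bonded ring carbon gives a 1.9-fold higher number from compound 2 to compound 3 (0.28 log units; within the scatter). Compound 3 therefore cannot be separated from compound 1 or compound 2, even though those two differ beyond the scatter, so the carboxy result does not show whether keeping the carbonyl matters here. No supporting evidence explains this result. Still open, from the compounds shown here alone, is whether a methyl ester, a primary amide or a methyl group at this position would separate clearly from compound 1 or compound 2.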